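A few compounds are considered here, and "the series" means these few. Any claim that something is new, unique, unknown or untested is made for them only; others in the source may bear on it.

Of the compounds shown here, three sharing one core have been tested in an assay on isolated protein (strain Sprague-Dawley) for inhibition of Amine oxidase [flavin-containing] A (Rattus norvegicus), read by spectrophotometry, with a stated time of 5 min, tested at 10 uM; a higher number here means more inhibition at the concentration tested (going by the name of the read-out), a lower number less inhibition. Compound 1 `CCCOc1cc(=O)oc2cc(OCc3ccccc3)ccc12` gives 0% in this assay. Compound 2 `COc1cc(=O)oc2cc(OCc3cccc(F)c3)ccc12` gives 49%. Compound 3 `CCOC(=O)COc1cc(=O)oc2cc(OCc3cccc(Cl)c3)ccc12` gives 0%, a reading level with compound 1 at the digits recorded, so the two stand together as the lowest of the three numbers; the nearest neighbour of compound 3 is compound 1, with no change beyond the scatter, and the furthest is compound 2, whose number lies beyond the scatter above it.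

Compound 4 `CCOC(=O)c1cc(=O)oc2cc(OCc3cccc(Cl)c3)ccc12` has not yet been measured. It differs from compound 3 in one place: ethoxycarbonyl in place of (ethoxycarbonyl)methoxy on an aromatic carbon. Among the measured compounds shown here, no step between two measured compounds isolates this change, so the size of its effect is open. The measured values of compound 1, compound 2 and compound 3 show that groups on this carbon can move the reading widely, but none of them tests an ethoxycarbonyl attached directly. The step from compound 3 to compound 4 is expected to be small and upward, a number 15 percentage points higher from compound 3 to compound 4 (beyond the scatter), most likely within the scatter. Compound 4 is therefore estimated at 15%, within a range from 0% to 45%.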

Compound 4, a percentage reported as inhibition, at one concentration (the size of the read-out at that concentration, not a potency): 4.4%
Estimate against measurement, compound 4: 10.6 percentage points above, within the range that was stated.
By their numbers in this assay, from the lowest: compounds 1, 3 and 4 (each within the scatter of the next); then compound 2.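

In this assay, among the compounds shown here, exchanging (ethoxycarbonyl)methoxy for ethoxycarbonyl on the aromatic carbon opposite the ring oxygen gives a number 4.4 percentage points higher from compound 3 to compound 4 (within the scatter), the first step in this set that isolates a single change at this position. With the rest of the molecule held constant, the two ester-bearing groups cannot be told apart in this assay, so whether the ester is attached directly to the aromatic carbon or carried on the longer (ethoxycarbonyl)methoxy group makes no difference that can be read here. Both readings also lie at the low end of the numbers seen so far, with compound 3 at 0% and compound 4 at 4.4%, and a single test concentration cannot show whether the two groups would separate at a higher one.

On these data alone, it remains open whether a carboxylic acid, an amide or an amine on this carbon, with the rest of compound 4 unchanged, would lift the reading clear of the scatter. Nothing among the data shown gives a reason why these two groups read alike.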